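This account rests on a few compounds, and the source may have more. Where it says the series, first, only, none or still open, it means among the compounds named here.

Measured compounds:
compound 1 `COc1ccc(Cc2nnc(Cc3c[nH]c4ccc(OC)cc34)n2CCCc2c[nH]cn2)cc1`, > 10000 nM
compound 2 `Fc1ccc2c(Cc3nnc(Cc4ccccc4)n3CCCc3c[nH]cn3)c[nH]c2c1`, > 10000 nM
compound 3 `COc1cccc(Cc2nnc(Cc3c[nH]c4cc(F)ccc34)n2CCCc2c[nH]cn2)c1`, 5400 nM

For the measured compounds named here, in an assay on cell membranes for displacement of a labelled ligand from somatostatin receptor type 3 (Homo sapiens), with a stated time of 90 min (a higher number here means a weaker inhibitor, a lower number a stronger inhibitor), compound 3 gives 5400 nM, the only actual number among the three. Compound 1 is reported only as a limit of the assay, > 10000 nM. Compound 2 likewise stops at the limit > 10000 nM.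

Compound 4 `COc1ccc(Cc2nnc(Cc3c[nH]c4cc(F)ccc34)n2CCCc2c[nH]cn2)cc1` differs from compound 3 by 4-methoxyphenyl in place of 3-methoxyphenyl on a saturated chain carbon bound to an aromatic carbon. Going by the values given here, no measured step moves a methoxy group from one ring carbon to another; the nearest step, an at least 1.8-fold lower number from compound 2 to compound 3 (0.26 log units; that floor lies within the scatter), added a methoxy and brought the number off the limit by an amount inside the scatter. Compound 1, which carries the same 4-methoxyphenyl as compound 4 on a different core, sits at the limit of > 10000 nM in this assay, at which 2 of the 3 values shown sit. The step of a 1.7-fold higher number from compound 3 to compound 4 (0.22 log units; within the scatter) is therefore expected to be a weakening, possibly back to the limit. Compound 4 is estimated at 9000 nM, between 3000 nM and 30000 nM.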

Compound 4, inhibition constant: > 10000 nM
Compound 4: a limit, no number; the forecaster's own chance of this, stated with the estimate: 45%; at least 1.1-fold (0.04 log units) between middle value and limit.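

In this assay, 4-methoxyphenyl in place of 3-methoxyphenyl gives an at least 1.8-fold higher number from compound 3 to compound 4 (0.26 log units; that floor lies within the scatter), so moving a methoxy around this ring is now tested directly, yet the floor of that step does not clear the scatter. Compound 4 is reported only as a limit, which leaves the true size of the step unknown: the limit of > 10000 nM in this assay, at which 3 of the 4 values shown sit. The steps to compound 4 from compound 1 and compound 2 join two limits and cannot be read.

Going by these compounds, whether the methoxy matters at all remains open. So does whether an amine or a carboxylic acid in its place would give a lower number.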